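This account rests on a few compounds, and the source may have more. Where it says the series, first, only, none or still open, it means among the compounds named here.

Three compounds have been examined so far in a toxicity assay on THP-1 cells (Homo sapiens) for inhibition; on this read-out higher numbers stand for lower toxicity in this test and lower numbers for higher toxicity in this test. Compound 1, with the structure `Cn1c(-c2ccccc2)cnc1NC(=O)c1cc(-c2ccccn2)[nH]n1`, reaches only a limit of the assay, and in this assay compound 1 gives > 50000 nM. Compound 2, with the structure `CCCC(=O)Nc1ncc(-c2ccc(OC)cc2)n1C`, likewise stops at a limit, and in this assay compound 2 gives > 100000 nM. Compound 3, with the structure `COc1ccc(CN(C)C(=O)NC(=O)c2ccc(F)cc2)cc1`, also ends at a limit, and in this assay compound 3 gives > 50000 nM. Compound 2 therefore stands at the limit of > 100000 nM in this assay, at which 1 of the 3 values shown sits, whereas the other two values sit at the limit of > 50000 nM in this assay, at which 2 of the 3 values shown sit. None of the three has shown measurable toxicity in the range tested, and no step between measured compounds is known.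

Compound 4, with the structure `COc1ccc(-c2cnc(NC(=O)c3cccc(Cl)c3)n2C)cc1`, is not yet measured. It differs from compound 2 in one place: 3-chlorophenyl in place of propyl on a carbonyl carbon. The propyl on the carbonyl carbon is swapped for a 3-chlorophenyl ring.

Among the measured compounds shown here, with every value so far a limit, no measured step can guide the expectation. No change beyond the usual scatter is expected for the step of an at least 1.2-fold lower number from compound 2 to compound 4 (0.09 log units; that floor lies within the scatter). Compound 4 is estimated at 80000 nM, within a range from 30000 nM to 200000 nM, with a good chance that the assay again reports only a limit.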

Compound 4, half-maximal cytotoxic concentration: > 28000 nM
Compound 4 gave a limit, no number; the forecaster's own chance of this, stated with the estimate: 75%; the middle value does not contradict the limit.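

In this assay compound 4 gives > 28000 nM, which is a limit of the assay and not a number. Compound 2 also stands at a limit, so no step can be read between compound 2 and compound 4. The compounds shown leave open whether 3-chlorophenyl in place of propyl on a carbonyl carbon changes the result in this assay at all.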